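Thiophene Replaces Chlorobenzyl at the Fused Core

The compounds below may be only part of what the source reports. "The series", "measured", "known", "first", "only" and "open" are said of these compounds alone.

Measured so far in a functional assay on L1210 cells (Mus musculus) for inhibition, read by cell counting, with a stated time of 2 days; a lower number here means a stronger inhibitor, a higher number a weaker inhibitor:
Compound 1 `C=C(Br)C(=O)Nc1cccc(-c2cn3nc(-c4ccc(OCC)cc4)sc3n2)c1` gives 790 nM.
Compound 2 `C=C(Br)C(=O)Nc1cccc(-c2cn3nc(Cc4ccc(Cl)cc4)sc3n2)c1` gives 2300 nM.

Compound 2 stands at the highest of the two numbers in this assay, with compound 1 lower by a 2.9-fold higher number from compound 1 to compound 2 (0.46 log units; beyond the scatter). Compound 3 `C=C(Br)C(=O)Nc1cccc(-c2cn3nc(-c4cccs4)sc3n2)c1` carries thiophen-2-yl in place of 4-chlorobenzyl on an aromatic carbon. For the measured compounds named here, the one step known, a 2.9-fold higher number from compound 1 to compound 2 (0.46 log units; beyond the scatter), swapped an aromatic ring for a benzyl group and raised the number by a modest amount; compound 3 returns to an aromatic ring, so part of that rise is expected to reverse. The estimate for compound 3 is 1200 nM (range 450 nM to 3000 nM), a step of a 1.9-fold lower number from compound 2 to compound 3 (0.28 log units; within the scatter) that is expected to be lower but near the scatter.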

Compound 3, half-maximal inhibitory concentration: 170 nM
The estimate for compound 3 lay 7.1-fold (0.85 log units) above the measured number; the measured number lies below the stated range.
By their numbers in this assay, from the lowest: compound 3; then compound 1; then compound 2.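

At this position, what matters is more than whether a ring is attached directly: in this assay, thiophen-2-yl outperforms the 4-chlorobenzyl group (a 14-fold lower number from compound 2 to compound 3 (1.13 log units; beyond the scatter)) and also the directly attached 4-ethoxyphenyl group (a 4.6-fold lower number from compound 1 to compound 3 (0.67 log units; beyond the scatter)). Two directly attached rings therefore give clearly different numbers, so the identity of the ring counts here as well. No supporting measurement accounts for this gain. Going by these compounds, it remains open whether the gain follows the ring sulfur or the five-membered ring itself. A furan-2-yl or unsubstituted phenyl group on this carbon would help separate the two.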